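From Methoxy to Anilino on a Shared Core

This account rests on a few compounds, and the source may have more. Where it says the series, first, only, none or still open, it means among the compounds named here.

Among the compounds with values here, only two compounds with this shared core have numbers so far. In an ADME assay on HepG2 cells (Homo sapiens) for cytotoxicity, read by CellTiter-Glo, with a stated time of 72 h (a higher number here means that more compound is needed for the effect, a lower number that less compound is needed), compound 1 (`C/C1=C/C2=C[C@H](C)C[C@@]23O[C@]2(CC(C)(C)C[C@@H]2[C@@H]1OC(=S)Sc1ccccc1)[C@@H](C)C3=O`) gives 26000 nM, and compound 2 (`CO[C@H]1[C@@H]2C(=O)/C(C)=C\C3=C[C@H](C)C[C@@]34O[C@]2(CC1(C)C)[C@@H](C)C4=O`) gives 26000 nM. Compound 2 therefore stands level with compound 1, and that single shared value is the only reference point.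

Compound 3 (`C/C1=C/C2=C[C@H](C)C[C@@]23O[C@]2(CC(C)(C)[C@@H](Nc4ccccc4)[C@@H]2C1=O)[C@@H](C)C3=O`) keeps the core of compound 2 but carries anilino in place of methoxy on a saturated ring carbon, part of a five-membered non-aromatic ring of carbon only. The change counts as follows: anilino in place of methoxy on a saturated ring carbon.

Within the data shown here, no measured pair shows what a change of this kind does, so any forecast here is tentative. In this assay, I expect a step that stays within the usual scatter, with a slight lean towards the lower number, meaning that less compound would be needed for the effect. The expected step, a 1.4-fold lower number from compound 2 to compound 3 (0.16 log units; within the scatter), is therefore small. The wide range below reflects how little has been measured. For compound 3, the estimated value is 18000 nM, with an expected range from 6000 nM to 45000 nM.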

Compound 3, half-maximal effective concentration: 26000 nM
Estimate against measurement, compound 3: 1.4-fold (0.16 log units) below; the measured number falls inside the stated range.
By their numbers in this assay, from the lowest: compounds 1, 2 and 3 (each within the scatter of the next).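

Putting anilino in place of methoxy on this saturated ring carbon gives, in this assay, no change at the digits printed from compound 2 to compound 3 (within the scatter). Within the data shown here, the position therefore takes on a six-membered aromatic ring of carbon only and a hydrogen-bond donor, neither of which methoxy has, and the reading for compound 3 stays level with that for compound 2, which is the first direct view of a change at this carbon. No further data bear on what lies behind this result.

Among these compounds, the single step brings in the aromatic ring and the donor together, so the contribution of each cannot be told apart, and a level reading for one replacement says little about how other groups would behave on this carbon. A plain amine would carry the donor without the ring, while a cyclohexyl group would carry a ring without the donor, and a carboxylic acid or a longer chain could show whether the reading stays level for groups of quite different kinds.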